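From a halogenated ring back to a hydroxylated one

A few compounds are considered here, and "the series" means these few. Any claim that something is new, unique, unknown or untested is made for them only; others in the source may bear on it.

Measured compounds:
- Compound 1 `COc1ccc(OC)c(/C=N/NC(=O)Nc2ccc(Oc3ccnc(-c4nncn4CCN(C)C)c3)c(F)c2)c1` gives 2070 nM in a functional assay on HT-29 cells (Homo sapiens) for cytotoxicity, read by MTT assay, with a stated time of 72 h; a lower number here means a stronger inhibitor, a higher number a weaker inhibitor.
- Compound 2 `CN(C)CCn1cnnc1-c1cc(Oc2ccc(NC(=O)N/N=C/c3ccc(O)c(O)c3)cc2F)ccn1` gives 1890 nM in this assay.
- Compound 3 `CN(C)CCn1cnnc1-c1cc(Oc2ccc(NC(=O)N/N=C/c3ccc(F)cc3Cl)cc2F)ccn1` gives 510 nM in this assay.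

Compound 3 has the lowest number of the three; compound 2 is nearest to it and compound 1 furthest, and both gaps lie beyond the scatter. Compound 4 `CN(C)CCn1cnnc1-c1cc(Oc2ccc(NC(=O)N/N=C/c3cccc(O)c3)cc2F)ccn1` differs from compound 3 in one place: 3-hydroxyphenyl in place of 2-chloro-4-fluorophenyl on a carbon with a double bond to nitrogen.

Going by the values given here, two measured steps bear on this change, each in the opposite direction. Moving from an oxygen-bearing ring to the 2-chloro-4-fluorophenyl gave a 4.1-fold lower number from compound 1 to compound 3 (0.61 log units; beyond the scatter) and a 3.7-fold lower number from compound 2 to compound 3 (0.57 log units; beyond the scatter). The two oxygen-bearing rings themselves sit close together, since a 1.1-fold lower number from compound 1 to compound 2 (0.04 log units; within the scatter). Returning to a hydroxyl-bearing ring is therefore expected to undo the gain, giving a modest rise in this assay, landing near compound 2. Compound 4 is expected to show a 3.5-fold higher number from compound 3 to compound 4 (0.55 log units; beyond the scatter). The estimated value for compound 4 is 1800 nM, with a likely range from 700 nM to 4500 nM.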

Compound 4, half-maximal inhibitory concentration: 330 nM
Compound 4: the middle estimate sits 5.5-fold (0.74 log units) above what was measured, outside the stated range (below it).
By their numbers in this assay, from the lowest: compounds 4 and 3 (each within the scatter of the next); then compounds 2 and 1 (each within the scatter of the next).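

In this assay, a ring bearing a hydroxyl can do as well as the halogenated one: a 1.5-fold lower number from compound 3 to compound 4 (0.19 log units; within the scatter), so among these compounds the 2-chloro-4-fluorophenyl holds no measurable edge over the 3-hydroxyphenyl. The oxygen-bearing rings also turn out not to behave as one family, since losing one hydroxy from the 3,4-dihydroxyphenyl gives a 5.7-fold lower number from compound 2 to compound 4 (0.76 log units; beyond the scatter), and the 3-hydroxyphenyl in place of 2,5-dimethoxyphenyl gives a 6.3-fold lower number from compound 1 to compound 4 (0.80 log units; beyond the scatter). At this position, then, the number depends on which oxygen groups the ring carries, not merely on whether it carries any.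

Nothing shown here explains why a single hydroxy differs from these other oxygen patterns. From the compounds shown here alone, it also remains open whether a phenyl ring carrying an amine or a carboxylic acid in place of the hydroxy would keep the number this low.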